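The source may hold more compounds than are shown below. What is called first, only, known or untested is meant among the compounds shown, and "the series" means these compounds.

Measured compounds in an assay on a protein complex for inhibition of integrin alpha-5/beta-1 (Homo sapiens), read by ELISA; on this read-out lower numbers stand for stronger inhibition and higher numbers for weaker inhibition:
- compound 1 `Cc1cc(C)c(S(=O)(=O)N[C@@H](CNC(=O)CO[C@@H]2C[C@@H](CNc3ccccn3)N(CCCc3ccccc3)C2)C(=O)O)c(C)c1`: 670 nM
- compound 2 `COc1ccnc(NC[C@@H]2C[C@@H](OCC(=O)NC[C@H](NC(=O)c3c(C)cc(C)cc3C)C(=O)O)CN2C(=O)CC(C)(C)C)c1`: 0.55 nM
- compound 3 `COc1ccnc(NC[C@@H]2C[C@@H](OCC(=O)NC[C@H](NS(=O)(=O)c3c(C)cc(C)cc3C)C(=O)O)CN2C(=O)CC(C)(C)C)c1`: 0.9 nM

Compound 1 gives the highest of the three numbers in this assay. Compound 2 and compound 3 sit far below it, and the two of them lie close together: the change a 1.6-fold higher number from compound 2 to compound 3 (0.21 log units; within the scatter) is within the scatter. Compound 2 and compound 3 differ from compound 1 in several places at once, so their gap to compound 1 cannot be assigned to any one group.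

Compound 4 `Cc1cc(C)c(S(=O)(=O)N[C@@H](CNC(=O)CO[C@@H]2C[C@@H](CNc3ccccn3)N(C(=O)OCc3ccccc3)C2)C(=O)O)c(C)c1` is the next member. It differs from compound 1 only at the ring nitrogen of the shared core: benzyloxycarbonyl in place of 3-phenylpropyl on an amine nitrogen in a ring. Among the compounds with values here, no measured pair isolates this change. Within the data shown here, the one measured step, from compound 2 to compound 3, concerns the group on the side-chain amine nitrogen and is small; it says nothing about the ring nitrogen. What can be noted is that compound 2 and compound 3, which carry a carbonyl-linked group on that ring nitrogen alongside their other differences, give very low numbers. On that slender basis a lower number is expected for compound 4 than for compound 1, with wide uncertainty: the step of a 3.4-fold lower number from compound 1 to compound 4 (0.53 log units; beyond the scatter) is the estimate. Compound 4 is therefore expected to give 200 nM in this assay, within a range from 30 nM to 1500 nM.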

Compound 4, half-maximal inhibitory concentration: 3.7 nM
For compound 4 the middle estimate is 54-fold (1.73 log units) above the measured one, outside the stated range (below it).
By their numbers in this assay, from the lowest: compounds 2 and 3 (each within the scatter of the next); then compound 4; then compound 1.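

Within the data shown here, at the amine nitrogen in a ring of the shared core, benzyloxycarbonyl in place of 3-phenylpropyl gives a 180-fold lower number from compound 1 to compound 4 (2.26 log units; beyond the scatter) in this assay, the only reading of this position on its own, as the earlier step concerned the side-chain amine nitrogen and stayed within the scatter. Both groups carry one six-membered aromatic ring of carbon only, so a large step at this position does not require a change in that ring; what differs is the link to it, with the entering group bringing a double bond outside aromatic rings and hydrogen-bond acceptors. Nothing measured on these compounds accounts for the size of this step.

From the compounds shown here alone, it remains open which part of the benzyloxycarbonyl link carries the step, a question that a 4-phenylbutanoyl group, with a carbonyl and a chain of carbon only, or a urea ending in a benzyl group would address on the core of compound 1. Going by these compounds, it also remains open how a free secondary amine on this ring nitrogen would read against compound 1 and compound 4.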